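A few compounds are considered here, and "the series" means these few. Any claim that something is new, unique, unknown or untested is made for them only; others in the source may bear on it.

Working notes on the series of quinone-type compounds built on the shared bicyclic sugar-fused core.

Compound 1 `Cc1ccc(NC2=CC(=O)c3nc4n(c3C2=O)[C@H]2OC[C@@H](O)[C@H]2OC4)cc1` carries a (4-methylphenyl)amino group on the core. In a functional assay on HeLa cells (Homo sapiens) for inhibition, read by sulforhodamine B assay (a higher number here means a weaker inhibitor, a lower number a stronger inhibitor), compound 1 gives 3860 nM. Compound 3 `CCOc1ccccc1NC1=CC(=O)c2c(nc3n2[C@H]2OC[C@@H](O)[C@H]2OC3)C1=O` has a (2-ethoxyphenyl)amino group in the same position and gives 8300 nM in this assay, a higher number than compound 1 and beyond the usual scatter. Compound 2 `O=C1C(N2CCCCC2)=CC(=O)c2c1nc1n2[C@H]2OC[C@@H](O)[C@H]2OC1`, which bears a piperidine in place of the aryl amine, reaches only the limit of this assay at > 16000 nM; this is a limit and not a number (the limit of > 16000 nM in this assay, at which 1 of the 3 values shown sits). For the measured compounds named here, of the two numbers known, compound 1 therefore stands lowest.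

Compound 4 `O=C1C=C(Nc2cccc(Cl)c2)C(=O)c2c1nc1n2[C@H]2OC[C@@H](O)[C@H]2OC1` is not yet measured. It differs from compound 1 in one place: 3-chlorophenyl in place of 4-methylphenyl on an amine nitrogen. The two known aryl amines sit within a narrow band, and the aryl-to-aryl swap here keeps that pattern, so the step from compound 1 to compound 4 is expected to be small, likely within scatter, with a slight lean toward a lower number a 1.3-fold lower number from compound 1 to compound 4 (0.11 log units; within the scatter). Compound 4 is thus estimated at 3000 nM in this assay, expected to fall between 1200 nM and 8000 nM.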

Compound 4, half-maximal inhibitory concentration: 6040 nM
Estimate against measurement, compound 4: 2.0-fold (0.30 log units) below; the measured number falls inside the stated range.
By their numbers in this assay, from the lowest: compounds 1, 4 and 3 (each within the scatter of the next, the first and the last beyond it). At a limit, above all of these: compound 2.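

In this assay, putting 3-chlorophenyl in place of 4-methylphenyl on the amine nitrogen gives a 1.6-fold higher number from compound 1 to compound 4 (0.19 log units; within the scatter), the only step shown so far that can be read as a single change at this position. Compound 1 and compound 4 therefore cannot be told apart in this assay, although both the substituent on the phenyl ring and its location on that ring change. Nothing measured in the compounds shown bears on the size of this step.

From the compounds shown here alone, compound 2, with piperidine in place of the aryl amine, gives > 16000 nM, which is a limit and not a number, so the size of that change stays unknown. Also open, going by these compounds, is how a benzylamine or a morpholine on this carbon of the shared core would read.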